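The source may report more compounds than this note shows. Statements on the series, on what has been measured and on what is new or still open speak of the compounds shown alone.

In a functional assay on HL-60 cells (Homo sapiens) for antiproliferative activity, read by MTT assay, with a stated time of 72 h (a lower number here means a stronger inhibitor, a higher number a weaker inhibitor), compound 3 `N=C(NS(=O)(=O)c1ccc(Cl)cc1)N1CCN(c2cc3c(cc2F)c(=O)c(C(=O)O)cn3C2CC2)CC1` gives 43 nM and stands level with two close relatives: compound 1 `CCn1cc(C(=O)O)c(=O)c2cc(F)c(N3CCN(C(=N)NS(=O)(=O)c4cccc(Cl)c4)CC3)cc21` gives 43 nM in the same test and compound 2 `CCn1cc(C(=O)O)c(=O)c2cc(F)c(N3CCN(C(=N)NS(=O)(=O)c4ccccc4)CC3)cc21` gives 43 nM as well. The next structure, compound 4 `CCn1cc(C(=O)O)c(=O)c2cc(F)c(N3CCN(C(=N)NS(=O)(=O)c4ccc(Cl)cc4)CC3)cc21`, differs from compound 3 in one place, with ethyl in place of cyclopropyl on an aromatic nitrogen and the rest of the molecule unchanged. Going by the values given here, no measured pair isolates this swap. Among the compounds with values here, the only measured step with a single change shows no change at the digits printed from compound 1 to compound 2 (within the scatter) when hydrogen stands in place of chloro on an aromatic carbon, which is a different part of the molecule, so it bears on the swap only loosely. Closer evidence comes from comparing the groups on that nitrogen: compound 1 and compound 2 carry ethyl, compound 3 carries cyclopropyl, and all three give the same value, although compound 3 also differs from them elsewhere. With compound 3 at 43 nM and compound 1 at 43 nM in this assay no shift beyond the scatter is expected, in either direction. The estimated outcome is no change at the digits printed from compound 3 to compound 4 (within the scatter) for this swap. Compound 4 is therefore expected at 43 nM with an estimated range from 21 nM to 90 nM in this test.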

Compound 4, half-maximal inhibitory concentration: 43 nM
For compound 4 middle estimate and measured number coincide at the digits printed; low and high end bracket the measured number.
By their numbers in this assay, from the lowest: compounds 1, 2, 3 and 4 (each within the scatter of the next).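

In this assay the swap on the aromatic nitrogen now has a direct reading, since ethyl in place of cyclopropyl gives no change at the digits printed from compound 3 to compound 4 (within the scatter) and the two groups cannot be told apart here when the rest of the molecule is held fixed. Compound 4 also completes a small set around the chlorine: chloro in place of hydrogen on an aromatic carbon gives no change at the digits printed from compound 2 to compound 4 (within the scatter) and 4-chlorophenyl in place of 3-chlorophenyl on the sulfonyl sulfur gives no change at the digits printed from compound 1 to compound 4 (within the scatter) in this test, so among these compounds neither having the chlorine nor moving it shifts the number. No measurement shown here offers an explanation for why these changes leave the result flat.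

All of these compounds share one value, so none of them shows what kind of change would shift the number in either direction. On these data alone, it remains open whether a longer chain such as butyl on that aromatic nitrogen, an amine on the phenyl ring, or a primary amide in place of the carboxy group would do so.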